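The source may report more compounds than this note shows. Statements on the series, on what has been measured and on what is new or still open speak of the compounds shown alone.

Going by the values given here, in a functional assay on SEM cells (Homo sapiens) for cytotoxicity, with a stated time of 72 h (on this read-out lower numbers stand for an effect already at smaller amounts and higher numbers for an effect only at larger amounts of compound), only two closely related compounds have been measured so far, compound 1 (`C=C[C@@](C)(/C=C/c1ccc(Nc2ccc(Cl)c(F)c2)cc1)CCC=C(C)C`) and compound 2 (`C=C[C@@](C)(/C=C/c1ccc(Nc2ccc(Cl)cc2)cc1)CCC=C(C)C`). Compound 1 gives > 36600 nM, which is a limit and not a number. Compound 2 gives > 36600 nM, which is likewise a limit. The position of compound 2 is therefore known only as the limit of > 36600 nM in this assay, at which 2 of the 2 values shown sit.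

The next compound, compound 3 (`C=C[C@@](C)(/C=C/c1ccc(Nc2ccc(Cl)c(Cl)c2)cc1)CCC=C(C)C`), differs from compound 2 in one place: chloro in place of hydrogen on an aromatic carbon. Chloro takes the place of hydrogen on an aromatic carbon, ortho to a chloro group and meta to a large group, so 4-chlorophenyl becomes 3,4-dichlorophenyl.

Among the compounds with values here, the one measured step that bears on this is also an exchange on that ring, hydrogen in place of fluoro: a step that the two limits leave unreadable from compound 1 to compound 2. It gives no size to carry over, and with nothing else to go on, the working expectation is no change beyond the scatter in this assay. The expected step is a number no higher from compound 2 to compound 3 (the limit leaves the size open). Compound 3 is estimated at 36600 nM, with an expected range of 15000 nM to 60000 nM, and may well be reported only as a limit.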

Compound 3, half-maximal effective concentration: > 36600 nM
Compound 3: a limit, no number; the forecaster's own chance of this, stated with the estimate: 75%; the middle value sits exactly at the limit.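

Compound 3 gives > 36600 nM in this assay, which is a limit and not a number. Going by these compounds alone, no step among compound 1, compound 2 and compound 3 can be read. The compounds shown leave open whether fluoro, hydrogen or chloro at this place on the ring makes any difference, because all three stop at one limit: the limit of > 36600 nM in this assay, at which 3 of the 3 values shown sit.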